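This account rests on a few compounds, and the source may have more. Where it says the series, first, only, none or still open, it means among the compounds named here.

Among the compounds with values here, compound 2 `COc1ccc(-c2cc(CN(c3nc4ccc(F)cc4s3)c3nc4ccc(OC)cc4s3)on2)cc1` shows the higher of the two numbers measured so far in a functional assay on MCF7 cells (Homo sapiens) for antiproliferative activity, read by MTT assay (on this read-out higher numbers stand for weaker inhibition and lower numbers for stronger inhibition), giving 32400 nM. Its nearest neighbour, compound 1 `COc1ccc2nc(N(Cc3cc(-c4ccc(SC(F)(F)F)cc4)no3)c3nc4ccc(F)cc4s3)sc2c1`, gives 14100 nM in this assay. Compound 3 `COc1ccc2nc(N(Cc3cc(-c4ccc(Br)cc4)no3)c3nc4ccc(F)cc4s3)sc2c1` differs from compound 2 by bromo in place of methoxy on an aromatic carbon. Within the data shown here, the one measured step touching this position is a 2.3-fold higher number from compound 1 to compound 2 (0.36 log units; beyond the scatter). Bromo is a different group from (trifluoromethyl)sulfanyl, so a downward step of similar or smaller size is expected. Compound 3 is therefore expected to give 18000 nM, within 8000 nM to 45000 nM. That estimate means a 1.8-fold lower number from compound 2 to compound 3 (0.26 log units; within the scatter), a modest lowering.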

Compound 3, half-maximal inhibitory concentration: 41200 nM
The estimate for compound 3 lay 2.3-fold (0.36 log units) below the measured number; measured number inside the range.
By their numbers in this assay, from the lowest: compound 1; then compounds 2 and 3 (each within the scatter of the next).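

Bromo in place of methoxy, on the same aromatic carbon, gives a 1.3-fold higher number from compound 2 to compound 3 (0.10 log units; within the scatter) in this assay and so separates these two groups no further than repeat measurements would. Bromo in place of (trifluoromethyl)sulfanyl gives a 2.9-fold higher number from compound 1 to compound 3 (0.47 log units; beyond the scatter) and so shows that, among these three groups, only (trifluoromethyl)sulfanyl stands apart at this position. Nothing available here explains this difference. Still open, as far as these compounds go, is whether an amine, a carboxylic acid or a longer chain at this position would bring the number below that of compound 1 or raise it further.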